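The source may hold more compounds than are shown below. What is called first, only, known or untested is meant among the compounds shown, and "the series" means these compounds.

Compound 1, `O=C(CN(c1nc(Cl)nc2[nH]cnc12)C1CC1)NCC(=O)OCc1ccccc1`: in a functional assay on the whole organism (Tail, strain ICR) with Mus musculus as the target, in the tail flick test, with a stated time of 120 min, at a dose of 25 umol/kg by the oral route (a higher number here means a stronger effect of the compound at the dose given, a lower number a weaker effect), compound 1 gives 21.7%.
Compound 2, `C[C@@H](O)[C@H](NC(=O)CN(c1ncnc2c1ncn2C1CCCCO1)C1CC1)C(=O)OCc1ccccc1`: in this assay compound 2 gives 10.9%.
Compound 3, `C[C@H](NC(=O)CN(c1nc(Cl)nc2[nH]cnc12)C1CC1)C(=O)O`: in this assay compound 3 gives 28.4%.

Among these three, compound 2 stands lowest in this assay; both compound 1 and compound 3 lie beyond the scatter above it. Compound 4, `CC(C)[C@H](NC(=O)CN(c1ncnc2c1ncn2C1CCCCO1)C1CC1)C(=O)OCc1ccccc1`, has not yet been measured. It differs from compound 2 in one place only: isopropyl in place of 1-hydroxyethyl on a saturated chain carbon bound to an amide-type nitrogen and a carbonyl carbon. Among the measured compounds shown here, no pair of measured compounds differs in a single place, so no measured step tells how much this kind of change moves this assay. Given that, the step is expected to be small in this assay, most likely a slight rise but possibly none beyond the scatter, with a number 5.1 percentage points higher from compound 2 to compound 4 (within the scatter) as the estimated step from compound 2 to compound 4. Compound 4 is therefore expected to give about 16%, in a range from 5% to 30%.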

Compound 4, a percentage reported as activity, at one dose (the size of the read-out at that dose, not a potency): 25.8%
Compound 4: middle estimate off by 9.8 percentage points, on the low side; the measured number falls inside the stated range.
By their numbers in this assay, from the lowest: compound 2; then compounds 1, 4 and 3 (each within the scatter of the next).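

Isopropyl in place of 1-hydroxyethyl on a saturated chain carbon bound to an amide-type nitrogen and a carbonyl carbon gives a number 14.9 percentage points higher from compound 2 to compound 4 (beyond the scatter) in this assay at this one dose. This first single-place step shows that the read-out responds to the group at this position, even though the heavy-atom count stays the same and only the hydrogen-bond donor and acceptor go. Nothing at hand explains the rise.

From the compounds shown here alone, whether a longer chain or an amine at this position would raise or lower the number remains open. Also open, going by these compounds, is whether the same change would have a similar effect on a different core.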